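Acyl variation on a furanolactone limonoid core

A few compounds are considered here, and "the series" means these few. Any claim that something is new, unique, unknown or untested is made for them only; others in the source may bear on it.

Measured so far:
compound 1 `C/C=C(\C)C(=O)O[C@H]1[C@]2(C)C[C@@H]3O[C@@]1(O)C=C1C4=CC(=O)O[C@@H](c5ccoc5)[C@]4(C)CC[C@@H]1[C@]3(C)[C@@H]2[C@@H](O)C(=O)OC`: 7700 nM
compound 2 `COC(=O)[C@H](O)[C@@H]1[C@@]2(C)C[C@@H]3O[C@@](O)(C=C4C5=CC(=O)O[C@@H](c6ccoc6)[C@]5(C)CC[C@@H]4[C@@]31C)[C@H]2O`: > 100000 nM
compound 3 `C/C=C(\C)C(=O)O[C@@H]1[C@]2(OC(=O)C(C)C)C=C3C4=CC(=O)O[C@@H](c5ccoc5)[C@]4(C)CC[C@@H]3[C@@]3(C)[C@H](C[C@]1(C)[C@H]3[C@@H](OC(=O)C(C)C)C(=O)OC)O2`: > 100000 nM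

For the measured compounds named here, in a functional assay on DU-145 cells (Homo sapiens) for inhibition, read by MTT assay, with a stated time of 24 h (a higher number here means a weaker inhibitor, a lower number a stronger inhibitor), compound 1 gives 7700 nM, the only numeric value in the set. Compound 2 sits at a limit, > 100000 nM. Compound 3 also sits at a limit, > 100000 nM. Going by the values given here, the one single-point step, an at least 12-fold higher number from compound 1 to compound 2 (1.11 log units; beyond the scatter), ends at the limit of > 100000 nM in this assay, at which 2 of the 3 values shown sit.

Compound 4 `C/C=C(\C)C(=O)O[C@@H]1[C@]2(OC(=O)CC)C=C3C4=CC(=O)O[C@@H](c5ccoc5)[C@]4(C)CC[C@@H]3[C@@]3(C)[C@H](C[C@]1(C)[C@H]3[C@@H](O)C(=O)OC)O2` carries propanoyl in place of hydrogen on an oxygen on a saturated carbon. Among the compounds with values here, no measured step covers this direction; compound 3, which differs from compound 1 in two places, shows only that a doubly acylated analogue reaches the limit. The expectation for compound 4 is therefore a weakening, a 3.2-fold higher number from compound 1 to compound 4 (0.51 log units; beyond the scatter), with a real chance of a limit. Compound 4 is estimated at 25000 nM, within 7000 nM to 100000 nM.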

Compound 4, half-maximal inhibitory concentration: 6700 nM
Compound 4: middle estimate off by 3.7-fold (0.57 log units), on the high side; measured number below the stated range.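

In this assay, the change from hydroxy to propanoyloxy on the core of compound 1 leaves the read-out level (a 1.1-fold lower number from compound 1 to compound 4 (0.06 log units; within the scatter)). This position therefore accepts a propanoyl group, and a free hydroxy on this oxygen is not needed to keep the activity of compound 1. Compound 4 gives a measured number and does not sit at the limit of the assay: (the limit of > 100000 nM in this assay, at which 2 of the 4 values shown sit).

On these data alone, whether this tolerance extends to a longer chain such as hexanoyl, or to benzoyl, on the same oxygen remains open. Also open, as far as these compounds go, is how a carboxylic acid or an amine carried on that acyl group would read.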